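Methoxy on the pendant phenyl in a stilbene-type series

This account rests on a few compounds, and the source may have more. Where it says the series, first, only, none or still open, it means among the compounds named here.

Measured so far, in a functional assay on RAW264.7 cells (Mus musculus) for inhibition, with stated times of 2 h and 24 h; a higher number here means a weaker inhibitor, a lower number a stronger inhibitor:
compound 1, `COc1ccc(/C=C2/c3cc(OC)cc(OC)c3[C@@H](c3ccc(OC)cc3)[C@@H]2c2cc(OC)cc(OC)c2)cc1`, 6260 nM
compound 2, `COc1ccc([C@@H]2c3c(OC)cc(OC)cc3/C(=C/c3ccccc3)[C@H]2c2cc(OC)cc(OC)c2)cc1`, > 200000 nM
compound 3, `COc1cc(OC)cc([C@@H]2C(C(O)c3ccccc3)c3cc(OC)cc(OC)c3[C@H]2c2ccccc2)c1`, 21600 nM

The value for compound 2 is a limit of this assay, not a number (the limit of > 200000 nM in this assay, at which 1 of the 3 values shown sits). The change from compound 2 to compound 1 is methoxy in place of hydrogen on an aromatic carbon, and the step is an at least 31-fold lower number from compound 2 to compound 1 (1.50 log units; beyond the scatter). How the core of compound 3 differs from that of compound 2 is not broken down here. Compound 4, `COc1ccc([C@@H]2c3c(OC)cc(OC)cc3C(C(O)c3ccccc3)[C@H]2c2cc(OC)cc(OC)c2)cc1`, has not yet been measured in this assay; it differs from compound 3 by methoxy in place of hydrogen on an aromatic carbon, the same change as from compound 2 to compound 1, at the same kind of place. Resting on that earlier step, a lower number is expected for compound 4, with the step estimated as a 7.2-fold lower number from compound 3 to compound 4 (0.86 log units; beyond the scatter), though the earlier step is anchored on a limit and its true size is unknown. The estimate for compound 4 is 3000 nM, between 600 nM and 15000 nM.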

Compound 4, half-maximal inhibitory concentration: > 200000 nM
Compound 4 gave a limit, no number; the forecaster's own chance of this, stated with the estimate: 5%; middle value at least 66-fold (1.82 log units) away from the limit.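

In this assay, methoxy in place of hydrogen on the aromatic carbon gives an at least 9.2-fold higher number from compound 3 to compound 4 (0.96 log units; beyond the scatter), so phenyl to 4-methoxyphenyl does not keep its direction from one core to the other: the same change on two cores in this assay, an at least 31-fold lower number (1.50 log units; beyond the scatter) from compound 2 to compound 1 and an at least 9.2-fold higher number (0.96 log units; beyond the scatter) from compound 3 to compound 4, at least 290-fold (2.47 log units) apart, beyond the scatter of two such steps. Compound 2 and compound 4 are both limits, so only the direction and a minimum size of each step can be read: the limit of > 200000 nM in this assay, at which 2 of the 4 values shown sit. These two cores do not show why the direction reverses, and they give no rule for other cores in the series.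

Still open, as far as these compounds go, is whether an amine or a carboxylic acid on the same aromatic carbon would also behave differently on the two cores.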